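Cytotoxicity notes: phenyl in place of benzyloxy

The source may hold more compounds than are shown below. What is called first, only, known or untested is meant among the compounds shown, and "the series" means these compounds.

Compound 1 `C=C[C@@](C)(/C=C/c1ccc(OCc2ccccc2)cc1)CCC=C(C)C` carries a benzyloxy group on the aromatic carbon para to the large side chain. In an ADME assay on HEK293 cells (Homo sapiens) for cytotoxicity, with a stated time of 72 h (on this read-out lower numbers stand for an effect already at smaller amounts and higher numbers for an effect only at larger amounts of compound), compound 1 gives only a limit, > 36600 nM, which is the limit of > 36600 nM in this assay, at which 1 of the 2 values shown sits. Compound 2 `C=C[C@@](C)(/C=C/c1ccc(O)c(/C=C/C(=O)c2ccccc2)c1)CCC=C(C)C` also reaches only a limit in this assay, > 7410 nM. Within the data shown here, compound 1 therefore stands at a limit, and the second value shown is a limit as well, so no measured step between the two compounds can be read; both simply show that no effect was reached within the tested range.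

Compound 3 `C=C[C@@](C)(/C=C/c1ccc(-c2ccccc2)cc1)CCC=C(C)C` is not yet measured. Compared with compound 1 the change is phenyl in place of benzyloxy on an aromatic carbon, placed on an aromatic carbon of a six-membered aromatic ring of carbon only, para to a large group. The benzyloxy group that leaves carries one hydrogen-bond acceptor; the phenyl that enters carries none.

With both shown values at limits, the step that the limit leaves unreadable from compound 1 to compound 3 is expected to be none beyond the scatter in this assay. Compound 3 is thus expected to give about 40000 nM, within 12000 nM to 120000 nM, most likely again as a limit.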

Compound 3, half-maximal effective concentration: > 36600 nM
Compound 3 ended at the assay's limit (the forecaster's own chance of this, stated with the estimate: 75%); the middle value does not contradict the limit.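

Compound 1 and compound 3 both end at a limit in this assay, so no step between them can be read: the limit of > 36600 nM in this assay, at which 2 of the 3 values shown sit.

The compounds shown leave open whether phenyl in place of benzyloxy on an aromatic carbon shifts the read-out at all, and at what concentration any compound of this series would reach an effect in this assay.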